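Methoxy added beside the phenol of a thiosemicarbazone

A few compounds are considered here, and "the series" means these few. Any claim that something is new, unique, unknown or untested is made for them only; others in the source may bear on it.

Compound 1 `CC1=CC[C@H](C(C)(C)NC(=S)N/N=C/c2ccc(O)cc2)CC1` is the phenolic member of a small set of thiosemicarbazones sharing one core. In a functional assay on HT-29 cells (Homo sapiens) for inhibition, read by sulforhodamine B assay, with a stated time of 48 h (a higher number here means a weaker inhibitor of growth, a lower number a stronger inhibitor of growth), compound 1 gives only a limit, > 100000 nM, and no number; it is one of the values that sit at the limit of > 100000 nM in this assay, at which 1 of the 3 values shown sits. Compound 2 `CC1=CC[C@H](C(C)(C)NC(=S)N/N=C/c2ccccc2Cl)CC1` gives 71300 nM in this assay, and compound 3 `CC1=CC[C@H](C(C)(C)NC(=S)N/N=C/c2cccc(Cl)c2)CC1` gives 7900 nM. The measured steps replace the whole 4-hydroxyphenyl group: an at least 1.4-fold lower number from compound 1 to compound 2 (0.14 log units; that floor lies within the scatter), and an at least 12-fold lower number from compound 1 to compound 3 (1.10 log units; beyond the scatter), while a 9.0-fold lower number from compound 2 to compound 3 (0.96 log units; beyond the scatter).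

Compound 4 `COc1cc(/C=N/NC(=S)NC(C)(C)[C@H]2CC=C(C)CC2)ccc1O` keeps the hydroxy group and differs from compound 1 by methoxy in place of hydrogen on an aromatic carbon, on an aromatic carbon of the six-membered carbon ring, ortho to the hydroxy group and meta to a large group. Going by the values given here, none of the measured steps adds a group to the retained ring; the two that start from compound 1 only show that its limit value can be left by changing the aryl group. With no closer guide, compound 4 is expected to stay weak, a step of an at least 1.2-fold lower number from compound 1 to compound 4 (0.09 log units; that floor lies within the scatter) that may again end at a limit. The estimate for compound 4 is 80000 nM, in the range 15000 nM to 300000 nM.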

Compound 4, concentration for 50% growth inhibition: < 40 nM
Compound 4 gave a limit, no number; the forecaster's own chance of this, stated with the estimate: 50%; middle value at least 2000-fold (3.30 log units) from the limit.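

Methoxy in place of hydrogen on an aromatic carbon, ortho to a hydroxy group and meta to a large group, gives an at least 2500-fold lower number from compound 1 to compound 4 (3.39 log units; beyond the scatter) in this assay. Thus, a single added group on the retained ring counts for more here than either replacement of the whole aryl group among the earlier compounds. Compound 4 holds a limit of the assay and not a number: the limit of < 40 nM in this assay, at which 1 of the 4 values shown sits. Compound 1 also holds a limit and not a number, so the step gives only a floor: the limit of > 100000 nM in this assay, at which 1 of the 4 values shown sits.

From the compounds shown here alone, it remains open whether methoxy would act the same way on a ring without the hydroxy group, such as the 3-chlorophenyl of compound 3. Also open, going by these compounds, is whether ethoxy or an amine at this position would keep the effect.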